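Trifluoromethyl in place of methyl: expectation for compound 4

A few compounds are considered here, and "the series" means these few. Any claim that something is new, unique, unknown or untested is made for them only; others in the source may bear on it.

Three compounds of the series have been run in an assay on isolated protein for inhibition of DNA topoisomerase 1 (Homo sapiens), with a stated time of 30 min, tested at 100 uM; on this read-out higher numbers stand for a stronger effect at the one concentration tested and lower numbers for a weaker effect. Compound 1 `Cc1cccc(-c2nc3ccc(C)cc3c(=O)[nH]2)c1` gives 75.7%, compound 2 `CCN(CC)c1ccc2nc(-c3ccccc3N(C)C)[nH]c(=O)c2c1` gives 82.1% and compound 3 `CCN(CC)c1ccc2nc(-c3ccccc3C(F)(F)F)[nH]c(=O)c2c1` gives 81.7%. Compound 1 carries the lowest of the three numbers, yet its gaps to compound 3 and to compound 2 both lie within the scatter, so no order among them is established. Among the compounds with values here, the one single-point step known, a number 0.4 percentage points lower from compound 2 to compound 3 (within the scatter), also lies within the scatter.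

Compound 4 `Cc1ccc2nc(-c3cccc(C(F)(F)F)c3)[nH]c(=O)c2c1` differs from compound 1 by trifluoromethyl in place of methyl on an aromatic carbon. Within the data shown here, the only comparable step, trifluoromethyl in place of dimethylamino on an aromatic carbon, moved the read-out by a number 0.4 percentage points lower from compound 2 to compound 3 (within the scatter), so a step no larger than the scatter is expected here, a number 1.3 percentage points higher from compound 1 to compound 4 (within the scatter). Compound 4 is therefore estimated at 77%, within 62% to 90%.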

Compound 4, a percentage reported as inhibition, at one concentration (the size of the read-out at that concentration, not a potency): 45.8%
For compound 4 the middle estimate is 31.2 percentage points above the measured one; measured number outside the range, below it.
By their numbers in this assay, from the lowest: compound 4; then compounds 1, 3 and 2 (each within the scatter of the next).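

In this assay, trifluoromethyl in place of methyl on an aromatic carbon, meta to a large group, gives a number 29.9 percentage points lower from compound 1 to compound 4 (beyond the scatter). Within the data shown here, this is the first step beyond the scatter, so the read-out does respond to the group at this position, which a number 0.4 percentage points lower from compound 2 to compound 3 (within the scatter) did not show for its own change. No available evidence bears on the reason for this step. From the compounds shown here alone, whether the fall belongs to trifluoromethyl alone or to any replacement of methyl at this position stays open. A methoxy group or a nitrile there would help separate the two readings.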